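The compounds below may be only part of what the source reports. "The series", "measured", "known", "first", "only" and "open" are said of these compounds alone.

Measured compounds:
compound 1 `O=C(CN1CCN(c2nnc(Cc3ccncc3)c3ccccc23)CC1)Nc1cccc(Br)c1`: 1350 nM
compound 2 `COc1ccc(NC(=O)CN2CCN(c3nnc(Cc4ccccc4)c4ccccc34)CC2)cc1OC`: 145000 nM
compound 3 `Cc1cccc(Cl)c1NC(=O)CN1CCN(c2nnc(Cc3ccccc3)c3ccccc23)CC1`: 53600 nM

In a functional assay on HT-29 cells (Homo sapiens) for cytotoxicity, read by MTT assay, with a stated time of 72 h (on this read-out higher numbers stand for weaker inhibition and lower numbers for stronger inhibition), compound 1 holds the lowest number of the three; compound 3 stands well above it, and compound 2 higher still. Compound 4 `O=C(CN1CCN(c2nnc(Cc3ccncc3)c3ccccc23)CC1)Nc1ccc(F)c(F)c1` keeps the core of compound 1 and differs only on the amide-type nitrogen: 3,4-difluorophenyl in place of 3-bromophenyl on an amide-type nitrogen. Among the compounds with values here, the one measured step, a 2.7-fold lower number from compound 2 to compound 3 (0.43 log units; beyond the scatter), also exchanges the group on that nitrogen, but on a different shared core and between different groups, so it only suggests that such exchanges shift the number modestly. Within the data shown here, no measured pair sets a 3-bromophenyl against a 3,4-difluorophenyl. A modest move upward is therefore expected for compound 4, a 2.2-fold higher number from compound 1 to compound 4 (0.35 log units; beyond the scatter), with the estimate 3000 nM and a range from 800 nM to 12000 nM.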

Compound 4, half-maximal inhibitory concentration: 2320 nM
For compound 4 the middle estimate is 1.3-fold (0.11 log units) above the measured one; the measured number falls inside the stated range.
By their numbers in this assay, from the lowest: compounds 1 and 4 (each within the scatter of the next); then compound 3; then compound 2.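

The exchange of 3-bromophenyl for 3,4-difluorophenyl on the amide-type nitrogen gives a 1.7-fold higher number from compound 1 to compound 4 (0.24 log units; within the scatter) in this assay on the shared core of compound 1. Within the data shown here, this is the first measured step at this position on that core, and it shows that one bromine can give way to two fluorines on the aromatic ring with no change this read-out can resolve.

As far as these compounds go, whether an amine, a carboxylic acid or a longer chain at this position would keep the number in that range remains open. The data shown give no reason for the result.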